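This account rests on a few compounds, and the source may have more. Where it says the series, first, only, none or still open, it means among the compounds named here.

Compound 1 has the structure `CCOC(=O)C1=C(S[C@@H]2CN[C@H](C(=O)Nc3cccc(C(=O)OCC)c3)C2)[C@H](C)[C@@H]2[C@@H]([C@@H](C)OC(=O)CC)C(=O)N12`. In an ADME assay for metabolic stability, read by LC-MS, with a stated time of 3 h, at pH 6.5, tested at 50 uM (a lower number here means that less of the compound is left, a higher number that more of the compound is left), compound 1 gives > 95%, which is a limit of the assay rather than a number. A second compound, compound 2, with the structure `C[C@@H](O)[C@H]1C(=O)N2C(C(=O)OCOC(=O)OC(C)(C)C)=C(S[C@@H]3CN[C@H](C(=O)Nc4cccc(C(=O)O)c4)C3)[C@H](C)[C@H]12`, was tested in the same way. In this assay compound 2 also gives > 95%, again a limit of the assay. This is the limit of > 95% in this assay, at which 2 of the 2 values shown sit, so the numbers shown give no step between measured compounds and no direction of change.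

Compound 3, with the structure `CCOC(=O)C1=C(S[C@@H]2CN[C@H](C(=O)Nc3cccc(C(=O)OCC)c3)C2)[C@H](C)[C@@H]2[C@@H]([C@@H](C)O)C(=O)N12`, has not been measured yet. It differs from compound 1 in one place: hydrogen in place of propanoyl on an oxygen on a saturated carbon. With both measured compounds at a limit, nothing shows how large a change this brings in this assay. The expectation is a step of a number no higher from compound 1 to compound 3 (the limit leaves the size open), none beyond the scatter. Compound 3 is estimated to give 95% in this assay, within a range from 85% to 99%.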

Compound 3, percent of the compound remaining: > 95%
Compound 3 ended at the assay's limit; the forecaster's own chance of this, stated with the estimate: 65%; the middle value sits exactly at the limit.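

Going by these compounds alone, compound 1 and compound 3 both sit at a limit of this assay rather than at a number, so no step between them can be read: the limit of > 95% in this assay, at which 3 of the 3 values shown sit. The compounds shown leave open whether hydrogen in place of propanoyl changes the percent of compound remaining at all, and by how much.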